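Series notes: methyl in place of 4-aminocyclohexyl

The source may hold more compounds than are shown below. What is called first, only, known or untested is meant among the compounds shown, and "the series" means these compounds.

Compounds measured so far:
compound 1, `COC(=O)c1nc(Br)c2cccnc2c1N[C@H]1CC[C@H](N)CC1`: > 20000 nM
compound 2, `NCCNc1c(C(=O)NCc2ccc(F)cc2)nc(Br)c2cccnc12`: 12000 nM
compound 3, `N[C@H]1CC[C@H](Nc2c(C(=O)NCc3ccc(F)cc3)nc(Br)c3cccnc23)CC1`: 6000 nM

Compound 1 sits at a limit of a functional assay on MDA-MB-435 cells (Homo sapiens) for cytotoxicity, read by MTT assay, with a stated time of 72 h (on this read-out higher numbers stand for weaker inhibition and lower numbers for stronger inhibition), rather than at a number; the value > 20000 nM is that limit (the limit of > 20000 nM in this assay, at which 1 of the 3 values shown sits). Compound 2 gives 12000 nM in this assay. Compound 3 gives 6000 nM, the lowest of the two numbers shown, though its separation from compound 2 is within the scatter.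

Two measured steps lead to compound 3. The step of an at least 3.3-fold lower number from compound 1 to compound 3 (0.52 log units; beyond the scatter) is beyond the scatter. The step of a 2.0-fold lower number from compound 2 to compound 3 (0.30 log units; within the scatter) is within the scatter, so the amine-bearing substituent on the aromatic nitrogen can be exchanged between 2-aminoethyl and 4-aminocyclohexyl without a clear change in this assay.

Compound 4, `CNc1c(C(=O)NCc2ccc(F)cc2)nc(Br)c2cccnc12`, is not yet measured. The change from compound 3 is methyl in place of 4-aminocyclohexyl on a nitrogen on an aromatic ring. Within the data shown here, no measured step removes the amine-bearing group altogether; the step from compound 2 to compound 3 bears on it only in that both retained an amine. The step is therefore expected to be modest and, if anything, toward a higher number in this assay.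

Compound 4 is estimated to give 15000 nM in this assay, with a range of 5000 nM to 40000 nM. The step this implies is expected to be a 2.5-fold higher number from compound 3 to compound 4 (0.40 log units; beyond the scatter).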

Compound 4, half-maximal inhibitory concentration: > 20000 nM
Compound 4: only a limit was reported; the forecaster's own chance of this, stated with the estimate: 30%; at least 1.3-fold (0.12 log units) between middle value and limit.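

With methyl in place of 4-aminocyclohexyl on this nitrogen, the series shows an at least 3.3-fold higher number from compound 3 to compound 4 (0.52 log units; beyond the scatter) in this assay. The group on this nitrogen therefore matters in a way that the pair compound 2 and compound 3 did not reveal, since their amine-bearing groups stay within the scatter of each other. The second step, an at least 1.6-fold higher number from compound 2 to compound 4 (0.22 log units; that floor lies within the scatter), has a floor within the scatter, so hydrogen in place of aminomethyl on the chain cannot yet be told apart from no change, and the value of compound 4 is a limit and not a number, which leaves both steps as floors only: the limit of > 20000 nM in this assay, at which 2 of the 4 values shown sit.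

Methyl removes the amine and the carbon frame of the substituent together, so the compounds shown do not say which of the two carries the difference between compound 3 and compound 4. A plain cyclohexyl without its amine, or a longer chain ending in an amine or in a carboxylic acid on this nitrogen, would separate these two parts, and would show whether any group here moves the series well past the level of compound 3.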